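Chloro for Methoxycarbonyl on a Quinoline Urea: Cytotoxicity Outlook

The source may report more compounds than this note shows. Statements on the series, on what has been measured and on what is new or still open speak of the compounds shown alone.

Measured so far:
compound 1, `COc1ccc(NC(=O)Nc2cc(C)nc3ccccc23)cc1OC`, > 25000 nM in an ADME assay on HepG2 cells (Homo sapiens) for cytotoxicity, with a stated time of 72 h; a higher number here means that more compound is needed for the effect, a lower number that less compound is needed
compound 2, `COC(=O)c1ccc(NC(=O)Nc2cc(C)nc3ccccc23)cc1`, 20000 nM

Of the compounds shown here, two sharing the same urea core have been tested for cytotoxicity. For compound 1 the result is only a limit of the assay, > 25000 nM, with no number behind it; this is the limit described in the limit of > 25000 nM in this assay, at which 1 of the 2 values shown sits. Among the measured compounds shown here, compound 2 is therefore the only compound with a real number, 20000 nM, and it stands alone on the scale. For the measured compounds named here, no step between two measured compounds can be drawn from this pair.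

Compound 3, `Cc1cc(NC(=O)Nc2ccc(Cl)cc2)c2ccccc2n1`, is not yet measured. It differs from compound 2 by a single change: chloro in place of methoxycarbonyl on an aromatic carbon. Going by the values given here, with no measured step to lean on, the expected size of the change from compound 2 to compound 3 is small, likely within the scatter, with a slight lean toward a lower number. Compound 3 is estimated at 15000 nM, between 5000 nM and 40000 nM, which would mean a step of a 1.3-fold lower number from compound 2 to compound 3 (0.12 log units; within the scatter).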

Compound 3, half-maximal effective concentration: > 25000 nM
Compound 3: a limit, no number; the forecaster's own chance of this, stated with the estimate: 35%; middle value at least 1.6-fold (0.22 log units) from the limit.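

At this aromatic carbon, para to a large group, putting chloro in place of methoxycarbonyl gives, in this assay, an at least 1.2-fold higher number from compound 2 to compound 3 (0.09 log units; that floor lies within the scatter). Compound 3 stands at a limit of the assay, so only the floor of this step is known, and that floor does not separate it from compound 2. The chloro compound thus joins compound 1 at the limit, leaving compound 2 as the only compound with a real number: the limit of > 25000 nM in this assay, at which 2 of the 3 values shown sit.

On these data alone, how far the true value of compound 3 lies past the limit remains open, and so does the full size of the step. As far as these compounds go, it is also open whether an amine, a carboxylic acid or a longer chain at this carbon would give a real number, and how that number would compare with compound 2.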